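The source may hold more compounds than are shown below. What is called first, only, known or untested is meant among the compounds shown, and "the series" means these compounds.

Compound 1 `O=[N+]([O-])c1c(CS(=O)(=O)c2ccccc2)nc2c(-c3ccc(Cl)cc3)cc(Cl)cn12` carries a chloro group on an aromatic carbon of its outer ring. In an ADME assay on HepG2 cells (Homo sapiens) for cytotoxicity, read by MTT assay, with a stated time of 72 h (on this read-out lower numbers stand for higher toxicity in this test and higher numbers for lower toxicity in this test), compound 1 gives > 3900 nM, which is a limit of the measurement and not a number. Compound 2 `COc1ccc(-c2cc(Cl)cn3c([N+](=O)[O-])c(CS(=O)(=O)c4ccccc4)nc23)cc1` has a methoxy in place of that chloro; in this assay compound 2 gives > 3900 nM, again a limit. Compound 3 `O=Cc1ccc(-c2cc(Cl)cn3c([N+](=O)[O-])c(CS(=O)(=O)c4ccccc4)nc23)cc1` bears a formyl instead; in this assay compound 3 gives > 31200 nM, also a limit. The step from compound 1 to compound 2 is a step that the two limits leave unreadable from compound 1 to compound 2, that from compound 1 to compound 3 is a step that the two limits leave unreadable from compound 1 to compound 3, and that from compound 2 to compound 3 is a step that the two limits leave unreadable from compound 2 to compound 3, because the limit of > 3900 nM in this assay, at which 2 of the 3 values shown sit, and the limit of > 31200 nM in this assay, at which 1 of the 3 values shown sits, leave no numbers to compare. Compound 4 `O=[N+]([O-])c1c(CS(=O)(=O)c2ccccc2)nc2c(-c3ccc(F)cc3)cc(Cl)cn12` differs from compound 1 by fluoro in place of chloro on an aromatic carbon. For the measured compounds named here, none of the measured steps resolves a change at this position, so compound 4 is expected to sit at 10000 nM in this assay, within 3900 nM to 50000 nM, most likely reported once more as a limit. The expected step is a step that the limit leaves unreadable from compound 1 to compound 4.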

Compound 4, half-maximal cytotoxic concentration: > 15600 nM
Compound 4: a limit, no number; the forecaster's own chance of this, stated with the estimate: 85%; at least 1.5-fold (0.19 log units) between middle value and limit.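

In this assay, for the compounds shown here, compound 4 also gives only a limit, so no step between it and compound 1, compound 2 or compound 3 can be read: the limit of > 15600 nM in this assay, at which 1 of the 4 values shown sits. The compounds shown leave open whether chloro, methoxy, formyl or fluoro at this place changes the half-maximal cytotoxic concentration at all.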